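A few compounds are considered here, and "the series" means these few. Any claim that something is new, unique, unknown or untested is made for them only; others in the source may bear on it.

Measured so far in an ADME assay on BJ cells (Homo sapiens) for cytotoxicity, read by CellTiter-Glo and resazurin assay, with a stated time of 72 h; on this read-out higher numbers stand for an effect only at larger amounts of compound and lower numbers for an effect already at smaller amounts:
Compound 1 `CC(C)N(Cc1cccc(OCCCCCC(=O)O)c1)C(=O)c1ccc(-c2cccc3ccccc23)cc1`: < 1.3 nM, a limit of the assay rather than a number.
Compound 2 `CC(C)N(Cc1cccc(OCCCCCC(=O)O)c1)C(=O)c1ccc(-c2cccc(-c3ccccc3)c2)cc1`: > 26000 nM, likewise a limit of the assay.

Compound 1 stands at the lower bound of this assay, so its position is known only as a bound (the limit of < 1.3 nM in this assay, at which 1 of the 2 values shown sits). Among the measured compounds shown here, the single measured step, an at least 20000-fold higher number from compound 1 to compound 2 (4.30 log units; beyond the scatter), runs from that lower bound to the upper bound (the limit of > 26000 nM in this assay, at which 1 of the 2 values shown sits); its true extent is open beyond the stated size.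

Compound 3 `CC(C)N(Cc1cccc(OCCCCCC(=O)O)c1)C(=O)c1ccc(-c2ccc3[nH]ccc3c2)cc1` is not yet measured. Its difference from compound 1: 1H-indol-5-yl in place of naphthalen-1-yl on an aromatic carbon. For the measured compounds named here, the only measured step bearing on this change is an at least 20000-fold higher number from compound 1 to compound 2 (4.30 log units; beyond the scatter), which shows that exchanging the naphthalen-1-yl group at this position can move the read-out by a very large amount. Compound 3 exchanges the same group for a different one, so for compound 3 the expected step is an at least 380-fold higher number from compound 1 to compound 3 (2.58 log units; beyond the scatter), an upward move toward an effect only at larger amounts, though with wide uncertainty. Compound 3 is therefore estimated at 500 nM in this assay, within the range 5 nM to 26000 nM.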

Compound 3, half-maximal effective concentration: > 26000 nM
Compound 3: no number, only a limit (the forecaster's own chance of this, stated with the estimate: 30%); at least 52-fold (1.71 log units) between middle value and limit.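

In this assay, a second replacement of naphthalen-1-yl, this time by 1H-indol-5-yl, gives an at least 20000-fold higher number from compound 1 to compound 3 (4.30 log units; beyond the scatter), so the large move at this place, on an aromatic carbon para to a large group, is no longer tied to 3-phenylphenyl alone. Compound 1 remains alone at the lower limit of the assay: the limit of < 1.3 nM in this assay, at which 1 of the 3 values shown sits. Compound 2 and compound 3 share the upper limit of the assay, so the step from one to the other cannot be read and no order of the two follows: the limit of > 26000 nM in this assay, at which 2 of the 3 values shown sit.

As far as these compounds go, with only limits at this place, the true sizes of the steps stay open, and so does whether a group such as phenyl, naphthalen-2-yl or quinolin-5-yl would give a real number inside the range of the assay. From the compounds shown here alone, it is also open whether the low limit of compound 1 holds when the carboxylic acid at the end of the chain gives way to a methyl ester or a primary amide, or when the chain is shorter.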